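Thiophene sulfonylureas: inhibition after the methoxy group is replaced

This account rests on a few compounds, and the source may have more. Where it says the series, first, only, none or still open, it means among the compounds named here.

Measured so far:
compound 1 `COc1ccc(S(=O)(=O)NC(=O)Nc2ccc(Cl)cc2)s1`: 93%
compound 2 `CCCc1ccc(S(=O)(=O)NC(=O)Nc2ccc(Cl)cc2)s1`: 38%

In a functional assay on the whole organism (6C3HED cells, Mus musculus) for inhibition, at a dose of 150 mg/kg by the oral route (on this read-out lower numbers stand for less inhibition and higher numbers for more inhibition at the one dose given (going by the name of the read-out)), compound 1 gives 93%, the higher of the two numbers recorded; compound 2 gives 38%. Among the measured compounds shown here, the one measured step, a number 55 percentage points lower from compound 1 to compound 2 (beyond the scatter), removes the methoxy group and is large.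

Compound 3 `Cc1ccsc1S(=O)(=O)NC(=O)Nc1ccc(Cl)cc1` is not yet measured. It differs from compound 1 as follows: 3-methylthiophen-2-yl in place of 5-methoxythiophen-2-yl on a sulfonyl sulfur. Here too the methoxy group leaves, so a loss beyond the scatter is expected in this assay, though a methyl entering elsewhere on the ring is not the same change as propyl entering. For compound 3 a value of 55% is estimated, within 20% to 85%. This corresponds to an expected step of a number 38 percentage points lower from compound 1 to compound 3 (beyond the scatter).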

Compound 3, a percentage reported as inhibition, in the whole organism at one dose (the size of the read-out at that dose, not a potency): 17%
The estimate for compound 3 lay 38 percentage points above the measured number, outside the stated range (below it).
By their numbers in this assay, from the lowest: compound 3; then compound 2; then compound 1.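

In this assay, 3-methylthiophen-2-yl in place of 5-methoxythiophen-2-yl on a sulfonyl sulfur gives a number 76 percentage points lower from compound 1 to compound 3 (beyond the scatter). Compound 2 and compound 3 both lack the methoxy group and both fall short of compound 1 beyond the scatter, so the loss is not confined to the propyl replacement. Nothing on hand bears on the reason for this loss.

As far as these compounds go, whether an ethoxy group or an amine in place of the methoxy group would hold the read-out in this assay remains open. Also open, from the compounds shown here alone, is how much of this step goes with the methyl group and how much with where it sits.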